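The compounds below may be only part of what the source reports. "The series", "measured", "known", "first", "only" and "open" are said of these compounds alone.

Measured so far:
compound 1 `CCCC/C=C\CCCCCCCCCc1cc(=O)c2c(O)cc(O)c(C)c2o1` gives 6790 nM in a functional assay on MDA-MB-231 cells (Homo sapiens) for antiproliferative activity, read by MTT assay; on this read-out higher numbers stand for weaker inhibition and lower numbers for stronger inhibition;
compound 2 `CCCC/C=C\CCCCCCCCCC1(O)CC(=O)c2c(O)cc(OCOC)cc2O1` gives 42800 nM in this assay;
compound 3 `CCCCC/C=C\C/C=C\CCCCCCCc1cc(=O)c2c(O)cc(O)c(C)c2o1` gives 6790 nM in this assay.

Compound 1 and compound 3 share a core; compound 3 carries deca-1,4-dien-1-yl in place of oct-3-en-1-yl on a saturated chain carbon, seven bonds along the chain from an aromatic carbon. That step reads no change at the digits printed from compound 1 to compound 3 (within the scatter). Compound 2 rests on another core; the difference between the two cores is not broken down here. Its number is the highest of the three, beyond the scatter from compound 1 and from compound 3.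

Compound 4 `CCCCC/C=C\C/C=C\CCCCCCCC1(O)CC(=O)c2c(O)cc(OCOC)cc2O1` awaits measurement. It carries deca-1,4-dien-1-yl in place of oct-3-en-1-yl on a saturated chain carbon, seven bonds along the chain from a saturated ring carbon. This is the same kind of change as before, not the same: the place lies seven bonds from a saturated ring carbon here, from an aromatic carbon there. The step of a 1.0-fold lower number from compound 2 to compound 4 (0.01 log units; within the scatter) is expected because the same kind of change gave no change at the digits printed from compound 1 to compound 3 (within the scatter). Compound 4 is estimated at 42000 nM, within 18000 nM to 95000 nM.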

Compound 4, half-maximal inhibitory concentration: 16100 nM
The estimate for compound 4 lay 2.6-fold (0.42 log units) above the measured number; measured number below the stated range.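

In this assay, deca-1,4-dien-1-yl in place of oct-3-en-1-yl gives a 2.7-fold lower number from compound 2 to compound 4 (0.42 log units; beyond the scatter) on the core of compound 2, and this step cannot be told apart from the earlier one on the core of compound 1: the same change on two cores in this assay, no change at the digits printed (within the scatter) from compound 1 to compound 3 and a 2.7-fold lower number (0.42 log units; beyond the scatter) from compound 2 to compound 4, 2.7-fold (0.42 log units) apart, within the scatter of two such steps. Among these compounds, the change therefore carries between these two cores without a measurable difference in size, although only the step on the core of compound 2 lies beyond the scatter. This does not show that the two cores respond identically, as each is represented by a single pair, and it gives no cause for either step.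

The compounds shown leave open how a longer chain would read on either core. They also leave open the effect of a carboxylic acid or an amine at the end of the chain.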